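From compound 2 to compound 3: one more methoxy

This account rests on a few compounds, and the source may have more. Where it says the series, first, only, none or still open, it means among the compounds named here.

In a functional assay on PC-3 cells (Homo sapiens) for cytotoxicity, read by colorimetric assay and MTT assay (on this read-out higher numbers stand for weaker inhibition and lower numbers for stronger inhibition), compound 1 (`COc1cccc2cc(-c3ccccc3)c(O)nc12`) gives 10000 nM and compound 2 (`COc1ccc(-c2cc3cccc(OC)c3nc2O)cc1`) gives 10000 nM as its reading. Compound 2 therefore stands level with compound 1 at the digits available, and the series offers no other measured neighbour. The next structure is compound 3 (`COc1ccc(-c2cc3c(OC)ccc(OC)c3nc2O)cc1`), reached from compound 2 by one replacement: methoxy in place of hydrogen on an aromatic carbon is the whole difference. The new methoxy sits on an aromatic carbon of a six-membered aromatic ring of carbon only, part of a fused or bridged system of two rings, para to a methoxy group.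

Within the data shown here, one measured step bears on this change. The step of no change at the digits printed from compound 1 to compound 2 (within the scatter) is also methoxy in place of hydrogen on an aromatic carbon, though elsewhere in the structure, and it stays within the scatter. A single step at another place is thin support, so no direction can be argued. In this assay the expected outcome is no shift beyond the scatter, and the estimated step of no change at the digits printed from compound 2 to compound 3 (within the scatter) reflects that. The estimate for compound 3 is 10000 nM with 4000 nM to 20000 nM as its expected range.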

Compound 3, half-maximal inhibitory concentration: 10000 nM
For compound 3 middle estimate and measured number coincide at the digits printed, and the stated range covers the measured number.
By their numbers in this assay, from the lowest: compounds 1, 2 and 3 (each within the scatter of the next).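

In this assay, among these compounds, the step of no change at the digits printed from compound 2 to compound 3 (within the scatter) gives the first reading for a methoxy on this aromatic carbon, para to a methoxy group, whereas the earlier step of no change at the digits printed from compound 1 to compound 2 (within the scatter) and its methoxy lie elsewhere in the structure. The same replacement has now been read at two different places, and compound 1, compound 2 and compound 3 stand level at the digits printed, so neither place yet separates itself from the other. Nothing measured in this set offers an explanation for this outcome.

With all three compounds level, the readings give no contrast by which the contribution of this position could be judged, and a second methoxy on the ring of carbon only tells nothing about other substituents there. From the compounds shown here alone, it remains open whether an amine, a carboxylic acid or a longer alkoxy chain at this aromatic carbon would read apart from compound 3, and whether changes to the hydroxyl group of the shared core would do so.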